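Swapping the aryl end of a curcumin-like linker for thiophene

The source may hold more compounds than are shown below. What is called first, only, known or untested is meant among the compounds shown, and "the series" means these compounds.

Three dienone compounds share a coumarin-bearing triazole tail and differ in the aromatic groups at the ends of the dienone chain. In a functional assay on HCT-116 cells (Homo sapiens) for inhibition, read by sulforhodamine B assay, with a stated time of 48 h, tested at 50 uM (on this read-out higher numbers stand for more inhibition of growth at the one concentration tested and lower numbers for less inhibition of growth), compound 1 `COc1ccccc1/C=C/C(=O)/C=C/c1ccc(OCc2cn(CCOc3cc(=O)oc4ccccc34)nn2)c(OC)c1` gives 70% and compound 3 `COc1cc(/C=C/C(=O)/C=C/c2cc(OC)c(OC)c(OC)c2)ccc1OCc1cn(CCCOc2cc(=O)oc3ccccc23)nn1` gives 76%. Compound 2 `COc1ccc(/C=C/C(=O)/C=C/c2ccc(OCc3cn(CCCCCOc4cc(=O)oc5ccccc45)nn3)c(OC)c2)cc1` gives 35% in this assay, the lowest of the three, with both others beyond the scatter above it. Compound 4 `COc1cc(/C=C/C(=O)/C=C/c2cccs2)ccc1OCc1cn(CCCCCOc2cc(=O)oc3ccccc23)nn1` is compound 2 with one change: thiophen-2-yl in place of 4-methoxyphenyl on a double-bonded chain carbon bound to a double-bonded chain carbon. Going by the values given here, no measured pair isolates this change, so its effect is unknown. Since no comparable step is shown, a step of a number 10 percentage points higher from compound 2 to compound 4 (within the scatter) is expected, modest and uncertain in direction. Compound 4 is estimated at 45%, plausibly between 20% and 70%.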

Compound 4, percent growth inhibition at one concentration: 31%
Beside the measured number, compound 4's estimate is 14 percentage points above it, and the stated range covers the measured number.
By their numbers in this assay, from the lowest: compounds 4 and 2 (each within the scatter of the next); then compounds 1 and 3 (each within the scatter of the next).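

In this assay, putting thiophen-2-yl in place of 4-methoxyphenyl on a double-bonded chain carbon bound to a double-bonded chain carbon gives a number 4 percentage points lower from compound 2 to compound 4 (within the scatter) in this one pair. At this place and with this tail, a smaller five-membered aromatic ring with one sulfur atom therefore reads the same as the larger six-membered carbon ring. No measurement here accounts for this result. Still open, from the compounds shown here alone, is whether an amine or a carboxylic acid on this end group would move the number. Also open, going by these compounds, is whether the same swap would read alike with the tails of compound 1 and compound 3.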